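The compounds below may be only part of what the source reports. "The series", "measured", "known", "first", "only" and "open" are said of these compounds alone.

Going by the values given here, compound 1 `Cc1cccc(/C=N/Nc2ncc3c(n2)n(C2CCCC2)c(=O)c(=O)n3C)c1` gives the highest number of the three measured so far: in a functional assay on PC-3 cells (Homo sapiens) for antiproliferative activity, read by MTT assay (a higher number here means a weaker inhibitor, a lower number a stronger inhibitor), compound 1 gives 53600 nM. Compound 2 `Cn1c(=O)c(=O)n(C2CCCC2)c2nc(N/N=C/c3cccc(Cl)c3Cl)ncc21` gives 17200 nM in this assay, and compound 3 `Cn1c(=O)c(=O)n(C2CCCC2)c2nc(N/N=C/c3ccc(O)c(Br)c3)ncc21` gives 11600 nM. The steps of a 3.1-fold lower number from compound 1 to compound 2 (0.49 log units; beyond the scatter) and a 4.6-fold lower number from compound 1 to compound 3 (0.66 log units; beyond the scatter) both lower the number modestly when a halogenated phenyl replaces the 3-methylphenyl, while a 1.5-fold lower number from compound 2 to compound 3 (0.17 log units; within the scatter) shows the two halogenated phenyls close together.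

Compound 4 `Cn1c(=O)c(=O)n(C2CCCC2)c2nc(N/N=C/c3ccc(F)cc3F)ncc21` differs from compound 1 in one place: 2,4-difluorophenyl in place of 3-methylphenyl on a carbon with a double bond to nitrogen. Both measured steps from compound 1 bear on it and both were modest lowerings, so a modest lowering in this assay is expected here too, estimated as a 2.7-fold lower number from compound 1 to compound 4 (0.43 log units; beyond the scatter). Compound 4 is thus expected to give about 20000 nM, in the range 8000 nM to 50000 nM.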

Compound 4, half-maximal inhibitory concentration: 13200 nM
For compound 4 the middle estimate is 1.5-fold (0.18 log units) above the measured one, and the stated range covers the measured number.
By their numbers in this assay, from the lowest: compounds 3, 4 and 2 (each within the scatter of the next); then compound 1.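

With 2,4-difluorophenyl on this carbon, a 4.1-fold lower number from compound 1 to compound 4 (0.61 log units; beyond the scatter) makes a third halogenated phenyl to give a modest lowering against the 3-methylphenyl in this assay. Fluorine now joins chlorine and bromine, yet a 1.1-fold higher number from compound 3 to compound 4 (0.06 log units; within the scatter) and a 1.3-fold lower number from compound 2 to compound 4 (0.11 log units; within the scatter) leave compound 2, compound 3 and compound 4 undistinguished despite their different halogens and substitution. Nothing available explains the gap to the 3-methylphenyl. Going by these compounds, whether the lowering follows the halogens or the loss of the methyl remains open. So does how an amine or a carboxylic acid on the phenyl would behave here.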